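A few compounds are considered here, and "the series" means these few. Any claim that something is new, unique, unknown or untested is made for them only; others in the source may bear on it.

Compound 1 `c1coc(CNc2nc(NCCCN3CCCC3)nc3ccccc23)c1`: "not determined" (no result reported)
Compound 2 `Clc1cccc(N2CCN(CCCCNc3nc(NCc4ccco4)c4ccccc4n3)CC2)c1Cl`: 95.8%

The measurement used here is a functional assay on MCF7 cells (Homo sapiens) for cytotoxicity, read by MTT assay, with a stated time of 2 days, tested at 10 uM; on this read-out lower numbers stand for less inhibition and higher numbers for more inhibition at the one concentration tested (going by the name of the read-out). For compound 1 the record shows "not determined" (no result reported), so no number stands for compound 1 and nothing can be said of where it sits on this scale. In this assay compound 2 gives 95.8%, a strong effect at the single concentration used. Within the data shown here, compound 1 and compound 2 differ at more than one place and no step between them is given, so their two values can only be set side by side, not compared as a change.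

Compound 3 `CCCCNc1nc(NCc2ccco2)c2ccccc2n1` has not yet been measured. Compared with compound 1 the change is methyl in place of pyrrolidin-1-yl on a saturated chain carbon, three bonds along the chain from a nitrogen on an aromatic ring. Among the measured compounds shown here, with compound 1 lacking a number, no step from compound 1 to compound 3 can be sized, and its direction remains open. For the measured compounds named here, the only number available, that of compound 2 at 95.8%, belongs to a compound whose chain carries a large ring-bearing end group, whereas compound 3 carries the shortest chain in the set, ending in methyl. Compound 3 is therefore expected to give about 45%, estimated to lie between 10% and 85%.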

Compound 3, a percentage reported as inhibition, at one concentration (the size of the read-out at that concentration, not a potency): 66.7%
Estimate against measurement, compound 3: 21.7 percentage points below, within the range that was stated.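

In this assay, among these compounds, compound 3 gives 66.7% while compound 1 shows "not determined" (no result reported) and so no step from compound 1 to compound 3 can be read. These compounds leave open what the change from 3-(pyrrolidin-1-yl)propyl to butyl does to the read-out. No evidence at hand bears on this result.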